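A Halogen Swap on the Aryl Ring of Compound 3

A few compounds are considered here, and "the series" means these few. Any claim that something is new, unique, unknown or untested is made for them only; others in the source may bear on it.

Going by the values given here, compound 3 `CCSC[C@@](O)([C@@H](Nc1cccc2nc(C)ccc12)c1ccc(F)cc1OC)C(F)(F)F` is one of three compounds measured so far in a functional assay on THP-1 cells (Homo sapiens) (on this read-out higher numbers stand for larger maximal responses and lower numbers for smaller maximal responses), where compound 3 gives 78%. Compound 1 `CC[C@H]1c2c(cc(F)c(F)c2O)[C@H](Nc2cccc3[nH]c(=O)ccc23)[C@@](O)(C(F)(F)F)C1OC` gives 78% in this assay, the same number at the digits shown, so the two stand together at the top of the three values without any order between them. Compound 2 `CCSC[C@@](O)([C@@H](Nc1cccc2nc(C)ccc12)c1cccc(F)c1OC)C(F)(F)F` gives 69%, and the step of a number 9 percentage points higher from compound 2 to compound 3 (within the scatter) shows how little the numbers moved when the fluorine on the aryl ring changed its place.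

Compound 4 `CCSC[C@@](O)([C@@H](Nc1cccc2nc(C)ccc12)c1ccc(Cl)c(F)c1OC)C(F)(F)F` is not yet measured. It differs from compound 3 at one spot: 4-chloro-3-fluoro-2-methoxyphenyl in place of 4-fluoro-2-methoxyphenyl on a saturated chain carbon bound to a nitrogen on an aromatic ring and a saturated chain carbon

Among the compounds with values here, the only measured step that bears on this change is the one from compound 2 to compound 3, which also altered the substitution of the same aryl ring and stayed within the scatter. Within the data shown here, no measured pair shows what adding a chlorine does here. The step is therefore expected to be small, a number 2 percentage points lower from compound 3 to compound 4 (within the scatter), with no direction that can be trusted. Compound 4 is estimated at 76% in this assay, with a range from 62% to 88%.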

Compound 4, largest response reached (Emax), in percent of the reference or control that the assay uses: 82%
Beside the measured number, compound 4's estimate is 6 percentage points below it; the range from low to high includes it.
By their numbers in this assay, from the lowest: compounds 2, 1, 3 and 4 (each within the scatter of the next, the first and the last beyond it).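

In this assay the swap of chloro in place of hydrogen on an aromatic carbon gives the only step shown so far that lies beyond the scatter: a number 13 percentage points higher from compound 2 to compound 4 (beyond the scatter) when a chlorine is added to the 3-fluoro-2-methoxyphenyl group, a modest effect but a readable one. The comparison with the 4-fluoro-2-methoxyphenyl group is less sharp, since the step is a number 4 percentage points higher from compound 3 to compound 4 (within the scatter) and this swap cannot be told apart from the noise of repeated measurements. Taken together, these two steps show that this aromatic ring, on a saturated chain carbon bound to a nitrogen on an aromatic ring and a saturated chain carbon, can carry a chlorine as well as a fluorine and a methoxy group while the maximal response stays high.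

No measurement shown explains what lies behind the step that the chlorine brings.

The compounds shown also leave open whether this step belongs to chlorine in particular, or whether a bromine, a methyl group or an amine on that same aromatic carbon would give a similar response.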